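Swapping an Acetoxy Group for a Triazolylsulfanyl Group

The source may report more compounds than this note shows. Statements on the series, on what has been measured and on what is new or still open speak of the compounds shown alone.

Measured compounds:
compound 1 `COc1cc(C2=NOC(CO[C@@H]3O[C@H](CSc4ncn[nH]4)[C@H]4OC5(CCCC5)O[C@@H]34)C2)cc(OC)c1OC` with 53000 nM
compound 2 `CC(=O)OC[C@H]1O[C@@H](OCc2noc(-c3ccc([N+](=O)[O-])cc3)n2)[C@@H]2OC3(CCCC3)O[C@@H]21` with 36000 nM

In a functional assay on WiDr cells (Homo sapiens) for antiproliferative activity, read by sulforhodamine B assay, with a stated time of 48 h (a lower number here means a stronger inhibitor of growth, a higher number a weaker inhibitor of growth), compound 2 gives 36000 nM, the lowest of the two numbers, while compound 1 gives 53000 nM, a gap within the scatter. Compound 3 `O=[N+]([O-])c1ccc(-c2nc(CO[C@@H]3O[C@H](CSc4ncn[nH]4)[C@H]4OC5(CCCC5)O[C@@H]34)no2)cc1` keeps the core of compound 2 and carries (1H-1,2,4-triazol-5-yl)sulfanyl in place of acetoxy on a saturated chain carbon bound to a saturated ring carbon. Compound 1 already bears this group on a related core and shows growth inhibition of the same weak order, so no step beyond the scatter is expected. Compound 3 is estimated at 40000 nM, between 15000 nM and 100000 nM, an expected step of a 1.1-fold higher number from compound 2 to compound 3 (0.05 log units; within the scatter).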

Compound 3, concentration for 50% growth inhibition: 20000 nM
Estimate against measurement, compound 3: 2.0-fold (0.30 log units) above; the measured number falls inside the stated range.
By their numbers in this assay, from the lowest: compounds 3, 2 and 1 (each within the scatter of the next, the first and the last beyond it).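

For the compounds shown here, this is the first pair that differs in one place only. In this assay, (1H-1,2,4-triazol-5-yl)sulfanyl in place of acetoxy on a saturated chain carbon bound to a saturated ring carbon gives a 1.8-fold lower number from compound 2 to compound 3 (0.26 log units; within the scatter), so on this core the two groups cannot be told apart. Nothing measured here bears on the reason for this result. Going by these compounds, whether an amine or a carboxylic acid at this place would move the number beyond the scatter stays open. So does the separate contribution of the sulfur and the triazole ring.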